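This account rests on a few compounds, and the source may have more. Where it says the series, first, only, none or still open, it means among the compounds named here.

Measured in a functional assay on DU-145 cells (Homo sapiens) for antiproliferative activity, read by MTT assay, with a stated time of 24 h; a higher number here means a weaker inhibitor, a lower number a stronger inhibitor:
Compound 1 `c1ccc(-c2noc(-c3ccncc3)n2)cc1`: 657000 nM as its value
Compound 2 `COc1ccc(-c2noc(C3CCCN3)n2)cc1OC1CCCC1`: 242000 nM as its value
Compound 3 `COc1cc(-c2noc(-c3ccncc3)n2)ccc1OCc1ccccc1`: > 1000000 nM as a limit of the assay, not a number

All of these values are large, so none of the three compounds is a strong inhibitor in this assay. Compound 2 at 242000 nM has the lower of the two true numbers. Compound 1 at 657000 nM is its nearest neighbour, and that gap lies beyond the usual scatter. For compound 3 only the limit of > 1000000 nM is known.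

The next compound to be tested is compound 4 `COc1ccc(-c2noc(-c3ccc(Cl)cc3)n2)cc1OC1CCCC1`. It keeps the rest of compound 2 but carries 4-chlorophenyl in place of pyrrolidin-2-yl on an aromatic carbon. Among the compounds with values here, no pair of measured compounds shows this change directly, so the expectation rests on thin evidence. Compound 1 also has an aromatic ring on that carbon and gives 657000 nM in the same assay, so a small move toward a higher number, and thus a weaker inhibitor, seems likely. That move may not clear the scatter. The expected change is a 1.7-fold higher number from compound 2 to compound 4 (0.22 log units; within the scatter) in size. For compound 4 the estimated value is 400000 nM with an expected range from 120000 nM to 1000000 nM in this assay.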

Compound 4, half-maximal inhibitory concentration: 123000 nM
Beside the measured number, compound 4's estimate is 3.3-fold (0.51 log units) above it; the range from low to high includes it.
By their numbers in this assay, from the lowest: compounds 4 and 2 (each within the scatter of the next); then compound 1. At a limit, above all of these: compound 3.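

Putting 4-chlorophenyl in place of pyrrolidin-2-yl on this aromatic carbon gives, in this assay, a 2.0-fold lower number from compound 2 to compound 4 (0.29 log units; within the scatter), so the two compounds cannot be told apart. Within the data shown here, the position therefore accepts a six-membered aromatic ring of carbon only in place of a five-membered non-aromatic ring with a hydrogen-bond donor and acceptor, and the earlier compounds could not show this, as no two of them differed in just one place. Compound 2 and compound 4 both give true numbers in this assay, so their step can be read, and only one of the values shown is a limit of the assay rather than a number: the limit of > 1000000 nM in this assay, at which 1 of the 4 values shown sits.

As far as these compounds go, it remains open what the chlorine itself contributes, and a plain phenyl ring on this carbon of the shared core would be the direct comparison. Also open, from the compounds shown here alone, is whether a quite different group here, such as an open-chain amine or a carboxylic acid, would move the number beyond the scatter, given that all the values shown are large and mark weak inhibitors.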